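A few compounds are considered here, and "the series" means these few. Any claim that something is new, unique, unknown or untested is made for them only; others in the source may bear on it.

In a functional assay on HeLa cells (Homo sapiens) for antiproliferative activity, read by sulforhodamine B assay, with a stated time of 48 h (on this read-out lower numbers stand for stronger inhibition of growth and higher numbers for weaker inhibition of growth), compound 1 `O=C1COc2ccccc2N1CCCn1cc(-c2ccccc2)nn1` gives 9000 nM. Compound 2 `COc1ccc(-c2cn(CCCN3C(=O)COc4ccccc43)nn2)cc1` gives 4900 nM, and the step of a 1.8-fold lower number from compound 1 to compound 2 (0.26 log units; within the scatter) leaves the two level. Compound 3 `O=C1COc2ccccc2N1CCCn1cc(-c2cccnc2)nn1` gives > 100000 nM, which is a limit and not a number.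

Compound 4 `O=C1COc2ccccc2N1CCCn1cc(CO)nn1` carries hydroxymethyl in place of phenyl on an aromatic carbon of the five-membered aromatic ring with 3 nitrogen: hydroxymethyl in place of phenyl on an aromatic carbon. The nearest measured change also replaces that phenyl, and the step of an at least 11-fold higher number from compound 1 to compound 3 (1.04 log units; beyond the scatter) is large. The step of an at least 20-fold higher number from compound 2 to compound 3 (1.30 log units; beyond the scatter) is also large and points the same way. A large move to a higher number in this assay is therefore expected, though only compound 3 supports it. The expected step is a 4.4-fold higher number from compound 1 to compound 4 (0.65 log units; beyond the scatter). Compound 4 is estimated at 40000 nM, with an expected range of 12000 nM to 100000 nM.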

Compound 4, concentration for 50% growth inhibition: 7300 nM
Compound 4: the middle estimate sits 5.5-fold (0.74 log units) above what was measured; measured number below the stated range.
By their numbers in this assay, from the lowest: compounds 2, 4 and 1 (each within the scatter of the next). At a limit, above all of these: compound 3.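

At this position, a ring on the five-membered aromatic ring with 3 nitrogen is not required in this assay: hydroxymethyl, with no ring, stays level with phenyl (a 1.2-fold lower number from compound 1 to compound 4 (0.09 log units; within the scatter)) and with 4-methoxyphenyl (a 1.5-fold higher number from compound 2 to compound 4 (0.17 log units; within the scatter)). Among the groups shown, pyridin-3-yl alone stands apart (an at least 13-fold lower number from compound 3 to compound 4 (1.13 log units; beyond the scatter)). The value of compound 3 is a limit and not a number: the limit of > 100000 nM in this assay, at which 1 of the 4 values shown sits.

From the compounds shown here alone, whether an amine or a carboxylic acid at this position would stay level with hydroxymethyl remains open. So does the outcome for a longer chain ending in hydroxyl.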